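This account rests on a few compounds, and the source may have more. Where it says the series, first, only, none or still open, it means among the compounds named here.

Compound 1 `COC(=O)c1cnc(C(=O)CCc2ccc(COc3ccccc3)cc2)o1`: in an assay for inhibition of Fatty-acid amide hydrolase 1 (Rattus norvegicus) (on this read-out higher numbers stand for weaker inhibition and lower numbers for stronger inhibition), compound 1 gives 1.6 nM
Compound 2 `O=C(O)c1ccc(-c2cnc(C(=O)CCc3ccc(COc4ccccc4)cc3)o2)nc1`: in this assay compound 2 gives 4.6 nM
Compound 3 `COC(=O)c1ccc(-c2cnc(C(=O)CCc3ccc(COc4ccccc4)cc3)o2)nc1`: in this assay compound 3 gives 3.5 nM

Among the three measured compounds, compound 3 holds the second highest number in this assay, though its gap to compound 2 is within the scatter, a 1.3-fold lower number from compound 2 to compound 3 (0.12 log units; within the scatter), and only its gap to compound 1 is beyond it, a 2.2-fold higher number from compound 1 to compound 3 (0.34 log units; beyond the scatter). Compound 4 `O=C(CCc1ccc(COc2ccccc2)cc1)c1ncc(-c2cccc(-c3nnn[nH]3)n2)o1` has not been measured. It differs from compound 3 at one place: 6-(1H-tetrazol-5-yl)pyridin-2-yl in place of 5-(methoxycarbonyl)pyridin-2-yl on an aromatic carbon. For the measured compounds named here, no measured step exchanges one acid-like group for another on this pyridine. The step nearest in kind is the one from the free acid to the methyl ester, a 1.3-fold lower number from compound 2 to compound 3 (0.12 log units; within the scatter), which stayed within the scatter, while replacing a small group on the shared core by a whole pyridine, a 2.9-fold higher number from compound 1 to compound 2 (0.46 log units; beyond the scatter) and a 2.2-fold higher number from compound 1 to compound 3 (0.34 log units; beyond the scatter), moved the numbers only modestly. Compound 4 is therefore expected to stay close to compound 3, with at most a modest shift, a 1.4-fold higher number from compound 3 to compound 4 (0.15 log units; within the scatter). The estimate for compound 4 in this assay is 5 nM, expected to lie between 1.5 nM and 16 nM.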

Compound 4, inhibition constant: 21 nM
Compound 4: middle estimate off by 4.2-fold (0.62 log units), on the low side; measured number above the stated range.
By their numbers in this assay, from the lowest: compound 1; then compounds 3 and 2 (each within the scatter of the next); then compound 4.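

For the compounds shown here, at this aromatic carbon next to the ring oxygen, the earlier compounds had tolerated a whole pyridine with only modest shifts, but the result shows that the outcome depends on what that pyridine carries. In this assay, 6-(1H-tetrazol-5-yl)pyridin-2-yl gives a 6.0-fold higher number from compound 3 to compound 4 (0.78 log units; beyond the scatter) and a 4.6-fold higher number from compound 2 to compound 4 (0.66 log units; beyond the scatter), so it stands apart from both the ester and the acid, which were within the scatter of each other. Going by these compounds alone, measured against the small methoxycarbonyl group, the change reaches a 13-fold higher number from compound 1 to compound 4 (1.12 log units; beyond the scatter), the only step at this position rated large, and nothing available explains why this group gives the highest number of the four.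

The compounds shown leave open whether this shift follows the 1H-tetrazol-5-yl group itself or its place on the pyridine, as the change from compound 2 or compound 3 alters both the group and where it sits. A 6-carboxypyridin-2-yl group or a 5-(1H-tetrazol-5-yl)pyridin-2-yl group at this aromatic carbon would separate the two, and neither is among the compounds here.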